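A new group on the amide-type nitrogen of compound 1

This account rests on a few compounds, and the source may have more. Where it says the series, first, only, none or still open, it means among the compounds named here.

Measured compounds:
compound 1 `O=C(Nc1ccc(Nc2ncnc3c2OCCN3)cc1)Nc1ccc(C(F)(F)F)cc1` — 2470 nM
compound 2 `COc1cccc(NC(=O)Nc2ccc(Nc3ncnc4c3OCCN4)cc2)c1` — > 10000 nM

Compound 1 `O=C(Nc1ccc(Nc2ncnc3c2OCCN3)cc1)Nc1ccc(C(F)(F)F)cc1` is the starting point. In an assay on isolated protein for inhibition of proto-oncogene tyrosine-protein kinase receptor Ret variant V804L (Homo sapiens), read by 33P incorporation, with stated times of 15 min and 40 min (a higher number here means a weaker inhibitor, a lower number a stronger inhibitor), compound 1 gives 2470 nM, and of the two results shown this is the only actual number. Compound 2 `COc1cccc(NC(=O)Nc2ccc(Nc3ncnc4c3OCCN4)cc2)c1` differs from compound 1 only in the group carried on the amide-type nitrogen, and in this assay compound 2 reaches just a limit, > 10000 nM. For the measured compounds named here, that exchange, an at least 4.0-fold higher number from compound 1 to compound 2 (0.60 log units; beyond the scatter), is the sole measured step at this position, and it rests on (the limit of > 10000 nM in this assay, at which 1 of the 2 values shown sits).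

Compound 3 `CC(C)(C)c1cc(NC(=O)Nc2ccc(Nc3ncnc4c3OCCN4)cc2)no1` has not yet been measured. Its structural change from compound 1 is 5-(tert-butyl)-1,2-oxazol-3-yl in place of 4-(trifluoromethyl)phenyl on an amide-type nitrogen. Going by the values given here, the one step that bears on it, an at least 4.0-fold higher number from compound 1 to compound 2 (0.60 log units; beyond the scatter), went toward weaker inhibition when the same group was swapped, but the incoming group there was a methoxyphenyl rather than a tert-butyl-bearing oxazole, so it is only a loose guide. Compound 3 is therefore expected to be a somewhat weaker inhibitor than compound 1, an estimated step of a 2.0-fold higher number from compound 1 to compound 3 (0.31 log units; beyond the scatter). The estimate for compound 3 in this assay is 5000 nM, within a range from 1500 nM to 15000 nM.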

Compound 3, half-maximal inhibitory concentration: 58 nM
For compound 3 the middle estimate is 86-fold (1.94 log units) above the measured one; measured number below the stated range.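

For the compounds shown here, until now the only step at this position pointed toward weaker inhibition, so the group on the amide-type nitrogen might have seemed to offer little room for gain. Compound 3 shows that this position can also strengthen inhibition a great deal: in this assay, 5-(tert-butyl)-1,2-oxazol-3-yl in place of 4-(trifluoromethyl)phenyl gives a 43-fold lower number from compound 1 to compound 3 (1.63 log units; beyond the scatter), while the same group in place of 3-methoxyphenyl gives an at least 170-fold lower number from compound 2 to compound 3 (2.23 log units; beyond the scatter). The value of compound 2 is a limit and not a number, so the second step has only a bound, and it rests on (the limit of > 10000 nM in this assay, at which 1 of the 3 values shown sits).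

The incoming group differs from both earlier groups in its ring and in carrying tert-butyl, so the compounds shown do not tell which of these features goes with the stronger inhibition. As far as these compounds go, a phenyl ring carrying tert-butyl, or the same 1,2-oxazole ring carrying a methyl group, would begin to separate the two, and whether any such gain holds for other groups on this nitrogen remains open.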